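A chlorine shifted within the same phenyl ring

This account rests on a few compounds, and the source may have more. Where it says the series, first, only, none or still open, it means among the compounds named here.

Measured compounds:
compound 1, `O=C(COc1cccc2ccccc12)N/N=C/c1ccc(Cl)cc1` — 4.54
compound 2, `C/C(=N\NC(=O)COc1cccc2ccccc12)c1cccc([N+](=O)[O-])c1` — 3.37
compound 3, `C/C(=N\NC(=O)COc1cccc2ccccc12)c1ccccc1O` — 3.08

In a physicochemical assay for lipophilicity, measured as octanol-water partition (a lower number here means a more polar compound, a higher number a more lipophilic compound), compound 1 gives the highest of the three numbers: compound 2 sits lower by a margin beyond the scatter, and compound 3 lies furthest below. Among the compounds with values here, the only step among measured pairs that differ in a single place is a number 0.29 log units lower from compound 2 to compound 3 (within the scatter), which stays within the scatter.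

Compound 4, `O=C(COc1cccc2ccccc12)N/N=C/c1cccc(Cl)c1`, differs from compound 1 by 3-chlorophenyl in place of 4-chlorophenyl on a carbon with a double bond to nitrogen. Within the data shown here, no measured step concerns this kind of change; the step between compound 2 and compound 3 exchanges one whole aryl group for another and does not bear on moving a chlorine within the same ring. The two compounds share every atom, and the chlorophenyl that enters has the same composition as the one that leaves, so no step beyond the scatter is expected in this assay. The expected step of a number 0.04 log units lower from compound 1 to compound 4 (within the scatter) is estimated to lie within the scatter. Compound 4 is therefore expected to give 4.5, in the range 4.15 to 4.85.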

Compound 4, partition coefficient: 4.54
The estimate for compound 4 lay 0.04 log units below the measured number, and the stated range covers the measured number.
By their numbers in this assay, from the lowest: compounds 3 and 2 (each within the scatter of the next); then compounds 1 and 4 (each within the scatter of the next).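

In this assay, replacing 4-chlorophenyl with 3-chlorophenyl on the carbon with a double bond to nitrogen gives no change at the digits printed from compound 1 to compound 4 (within the scatter) and so separates neither compound from the other. This is the only step shown that keeps the composition of the group fixed and alters only where the chlorine stands on the phenyl ring, whereas the earlier step exchanged one whole aryl group for another. At this place, with this substituent, the two chlorophenyl groups cannot be told apart by this read-out, and nothing shown offers an explanation for that result. 

The compounds shown leave open whether an amine or a carboxylic acid in place of the chlorine would give a step of similar size. They also leave open whether moving a nitro or hydroxyl group around its ring would give the same result as moving the chlorine.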